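The source may hold more compounds than are shown below. What is called first, only, known or untested is meant among the compounds shown, and "the series" means these compounds.

Compound 1, `CCCOc1ccccc1-c1ncc(C(=O)O)c(=O)[nH]1`, gives 0.9 mg/kg in a functional assay on the whole organism (strain Sprague-Dawley) for inhibition, with Rattus norvegicus as the target, with a stated time of 10 min; a higher number here means that more compound is needed for the effect, a lower number that less compound is needed.
Compound 2, `CCOC(=O)c1cnc(-c2ccccc2F)[nH]c1=O`, reaches only the limit of this assay, > 10 mg/kg.
Compound 3, `CCCOc1ccccc1-c1ncc(C(=O)OCC)c(=O)[nH]1`, gives 5 mg/kg in this assay.

Of the two actual numbers, compound 3 carries the higher one, so more of it is needed than of compound 1; the gap between them is a 5.6-fold higher number from compound 1 to compound 3 (0.74 log units; beyond the scatter), and it comes from the ester carrying ethyl instead of hydrogen. Compound 4, `CCOC(=O)c1cnc(-c2ccccc2SC)[nH]c1=O`, differs from compound 3 by methylsulfanyl in place of propoxy on an aromatic carbon.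

Among the compounds with values here, only one measured step touches this position: an at least 2.0-fold lower number from compound 2 to compound 3 (0.30 log units; that floor lies within the scatter), where fluoro gave way to propoxy. One end of that step is merely (the limit of > 10 mg/kg in this assay, at which 1 of the 3 values shown sits), so it sets no clear direction, and the two numbered compounds differ at a different place. Within the data shown here, the change to methylsulfanyl is a third substituent at the same position, with no direct precedent. The expectation is therefore a step in this assay of no more than the usual scatter, most likely a slightly higher number, as a 1.2-fold higher number from compound 3 to compound 4 (0.08 log units; within the scatter). Compound 4 is estimated at 6 mg/kg, with a range from 2 mg/kg to 15 mg/kg, and a real chance that only a limit is reported.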

Compound 4, dose for 50% inhibition: > 25 mg/kg
Compound 4: a limit, no number; the forecaster's own chance of this, stated with the estimate: 35%; middle value at least 4.1-fold (0.61 log units) away from the limit.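

With the ethyl ester kept in place, putting methylsulfanyl in place of propoxy on this aromatic carbon, ortho to a large group, gives an at least 5.0-fold higher number from compound 3 to compound 4 (0.69 log units; beyond the scatter) and so, unlike the earlier step from fluoro, this change shows a clear direction at this position. Compound 4 reaches only a limit in this assay, so this step is a floor and not a full measure of the gap: the limit of > 25 mg/kg in this assay, at which 1 of the 4 values shown sits. Among the ethyl esters shown, only compound 3, with propoxy, gives an actual number, while the fluoro and methylsulfanyl compounds both end at limits, so the step between compound 2 and compound 4 cannot be read.

The compounds shown cannot separate the length of the propoxy chain from its oxygen, since methylsulfanyl differs in both, and they give no reason for the loss. A propylsulfanyl chain or an amine on this same aromatic carbon would help to separate these, and methylsulfanyl paired with the free carboxylic acid of compound 1 would show whether the acid still needs less compound with this group.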